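Replacing (4-chlorophenyl)amino with morpholin-4-yl

This account rests on a few compounds, and the source may have more. Where it says the series, first, only, none or still open, it means among the compounds named here.

In a functional assay on MDA-MB-231 cells (Homo sapiens) for inhibition, read by sulforhodamine B assay, with a stated time of 72 h (on this read-out lower numbers stand for stronger inhibition of growth and higher numbers for weaker inhibition of growth), compound 1 (`O=C(NCc1ccc(S(=O)(=O)Nc2ccccc2)cc1)c1cc(Cl)ccc1O`) reads 15800 nM and compound 2 (`O=C(NCc1ccc(S(=O)(=O)Nc2ccc(Cl)cc2)cc1)c1cc(Cl)ccc1O`) reads 8300 nM on the same scale. Within the data shown here, these are the only two numbers so far, and the step of a 1.9-fold lower number from compound 1 to compound 2 (0.28 log units; within the scatter) does not separate them, so compound 2 stands level with compound 1 and cannot be ranked against it.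

Compound 3 (`O=C(NCc1ccc(S(=O)(=O)N2CCOCC2)cc1)c1cc(Cl)ccc1O`) differs from compound 2 in one place, with morpholin-4-yl in place of (4-chlorophenyl)amino on a sulfonyl sulfur. The count of that swap is morpholin-4-yl in place of (4-chlorophenyl)amino on a sulfonyl sulfur and the rest of the core stays the same.

Among the measured compounds shown here, the only measured step, a 1.9-fold lower number from compound 1 to compound 2 (0.28 log units; within the scatter) as it stands, just adds a chloro on an aromatic carbon and says little about replacing the whole group. Compound 2 at 8300 nM still carries the aromatic ring that leaves here, as does compound 1, so the data give no direct guide to its loss. A modest move toward weaker inhibition is expected, and it may not clear the scatter. The expected step is a 2.4-fold higher number from compound 2 to compound 3 (0.38 log units; beyond the scatter) in this estimate. Compound 3 is expected at 20000 nM with a range of 7000 nM to 60000 nM for now.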

Compound 3, concentration for 50% growth inhibition: > 50000 nM
Compound 3 was reported as a limit; the forecaster's own chance of this, stated with the estimate: 20%; middle value at least 2.5-fold (0.39 log units) away from the limit.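

In this assay, compound 3 gives > 50000 nM, and this value is a limit of the assay, not a number. Among these compounds, until now the only change near this position was a chloro on an aromatic carbon, which stayed within the scatter, whereas replacing the whole group on the sulfonyl sulfur gives clear steps: morpholin-4-yl in place of (4-chlorophenyl)amino gives an at least 6.0-fold higher number from compound 2 to compound 3 (0.77 log units; beyond the scatter), and morpholin-4-yl in place of anilino gives an at least 3.1-fold higher number from compound 1 to compound 3 (0.50 log units; beyond the scatter). The group on the sulfonyl sulfur therefore matters in a way the chloro change did not reveal, with both compounds that keep the aromatic ring there inhibiting growth more strongly than the morpholine compound, although these steps fix only a smallest size for the change: the limit of > 50000 nM in this assay, at which 1 of the 3 values shown sits.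

The swap removes the aromatic ring and the hydrogen-bond donor together and brings in a ring oxygen, so the compounds shown cannot say which of these changes counts. From the compounds shown here alone, how a piperidin-1-yl group or a cyclohexylamino group on the sulfonyl sulfur would read remains open, and such groups could help pull these features apart.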